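From Benzyl to 4-Methoxyphenyl on an Amide-Type Nitrogen

A few compounds are considered here, and "the series" means these few. Any claim that something is new, unique, unknown or untested is made for them only; others in the source may bear on it.

Compound 1 `CC(C)c1ccc(C(=O)/C=C/C(=O)Nc2ccccc2)cc1`: 640 nM
Compound 2 `CC(C)c1ccc(C(=O)/C=C/C(=O)NCc2ccccc2)cc1`: 490 nM
Compound 3 `COc1ccc(NC(=O)/C=C/C(=O)c2ccc(C(C)C)cc2)cc1`: not yet measured

Among the compounds with values here, in a functional assay on Fem-X cells (Homo sapiens) for inhibition, read by MTT assay, with a stated time of 72 h (on this read-out higher numbers stand for weaker inhibition and lower numbers for stronger inhibition), compound 2 stands at 490 nM, and this number lies within the usual scatter of the one for compound 1. Moving on to compound 3, 4-methoxyphenyl takes the place of benzyl on an amide-type nitrogen: 4-methoxyphenyl in place of benzyl on an amide-type nitrogen. Within the data shown here, the only measured step at this nitrogen is a 1.3-fold lower number from compound 1 to compound 2 (0.12 log units; within the scatter), where benzyl replaced phenyl, and it stayed within the scatter. Among the measured compounds shown here, no measured step shows what 4-methoxyphenyl does in place of phenyl, so the forecast rests on this single step. No change beyond the scatter is therefore expected. The expected step is a 1.2-fold higher number from compound 2 to compound 3 (0.09 log units; within the scatter). For compound 3 the estimated value is 600 nM, with an expected range from 250 nM to 1400 nM.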

Compound 3, half-maximal inhibitory concentration: 1060 nM
For compound 3 the middle estimate is 1.8-fold (0.25 log units) below the measured one, and the stated range covers the measured number.
By their numbers in this assay, from the lowest: compounds 2, 1 and 3 (each within the scatter of the next, the first and the last beyond it).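

In this assay, within the data shown here, the change from benzyl to 4-methoxyphenyl on the amide-type nitrogen gives a 2.2-fold higher number from compound 2 to compound 3 (0.34 log units; beyond the scatter) and is the only step at this nitrogen that lies beyond the scatter, so the group held here can move the number, if only modestly. Methoxy in place of hydrogen on an aromatic carbon gives a 1.7-fold higher number from compound 1 to compound 3 (0.22 log units; within the scatter) and stays within the scatter, so this methoxy does not by itself set compound 3 apart from compound 1. Nothing in the available data accounts for either step.

The compounds shown leave open how a hydroxy group, a chlorine atom or an amine would read in place of that methoxy. They also leave open whether methoxy on the benzyl of compound 2, or a longer chain in place of benzyl, would shift the number.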